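Pyrazinyl to Fluorophenyl on a Pyrazole Carboxylic Acid

This account rests on a few compounds, and the source may have more. Where it says the series, first, only, none or still open, it means among the compounds named here.

Measured so far:
compound 1 `CCSc1sc(-n2nc(C)c(Cc3ccccc3[N+](=O)[O-])c2C(=O)O)nc1-c1ccc(Cl)c(Cl)c1` — 59000 nM
compound 2 `Cc1nn(-c2nc(-c3ccc(Cl)c(Cl)c3)c(SC(C)C)s2)c(C(=O)O)c1-c1cnccn1` — 14000 nM

Of the compounds shown here, two have been tested in a functional assay on BJAB cells (Homo sapiens) for antiproliferative activity, with a stated time of 4 days; on this read-out higher numbers stand for an effect only at larger amounts of compound and lower numbers for an effect already at smaller amounts. Compound 1 gives 59000 nM, whereas compound 2 gives 14000 nM, the lowest of the two numbers; the gap between them lies beyond the usual scatter, so compound 2 stands as the more active of the pair in this assay.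

Compound 3 `Cc1nn(-c2nc(-c3ccc(Cl)c(Cl)c3)c(SC(C)C)s2)c(C(=O)O)c1-c1cccc(F)c1` has not yet been measured. It differs from compound 2 by 3-fluorophenyl in place of pyrazin-2-yl on an aromatic carbon. Going by the values given here, no measured pair shows this kind of exchange, so its effect in this assay cannot be read from the numbers in hand. Given that compound 2 gives 14000 nM, compound 3 is expected to stay in the same region, with a step of a 1.4-fold lower number from compound 2 to compound 3 (0.15 log units; within the scatter) that is expected to be small and not clearly beyond the scatter. Compound 3 is therefore estimated at 10000 nM in this assay, within a range from 3000 nM to 40000 nM.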

Compound 3, half-maximal effective concentration: 900 nM
Beside the measured number, compound 3's estimate is 11-fold (1.05 log units) above it; measured number outside the range, below it.
By their numbers in this assay, from the lowest: compound 3; then compound 2; then compound 1.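

In this assay the group on the aromatic carbon next to the ring atom that bears a carboxy group turns out to matter a great deal: 3-fluorophenyl in place of pyrazin-2-yl gives a 16-fold lower number from compound 2 to compound 3 (1.19 log units; beyond the scatter) and puts compound 3 lowest of the three numbers. Going by these compounds alone, compound 1 and compound 2 differ in more than one place, so this is the first change that can be read at a single position. Nothing measured here accounts for the size of this step.

The compounds shown leave open whether the step follows from the fluorine or from the carbon-only ring. On these data alone, an unsubstituted phenyl or a pyridin-2-yl at this position would separate the two, and the same exchange is untested on compounds carrying an ethylthio group in place of the isopropylthio group.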